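Two triazolothiadiazoles share a methoxy-to-hydrogen step

A few compounds are considered here, and "the series" means these few. Any claim that something is new, unique, unknown or untested is made for them only; others in the source may bear on it.

Of the compounds shown here, three from this series have been tested in a functional assay on the whole organism (strain Wistar Albino) for inhibition, with Rattus norvegicus as the target, read by paw edema, with a stated time of 2 h, at a dose of 20 mg/kg; on this read-out higher numbers stand for more inhibition at the one dose given (going by the name of the read-out) and lower numbers for less inhibition. Compound 1, `COc1ccc(Cl)c(-c2nnc3sc(Cc4c[nH]c5ccc(OC)cc45)nn23)c1`, gives 14.4%. Compound 3, `COc1ccc(Cl)c(-c2nnc3sc(Cc4c[nH]c5ccccc45)nn23)c1`, gives 16.5%. These two are related by a single change, (hydrogen in place of methoxy on an aromatic carbon), and the step of a number 2.1 percentage points higher from compound 1 to compound 3 (within the scatter) is one that the usual scatter of repeated measurements can account for. Compound 2, `COc1ccc2[nH]cc(Cc3nn4c(Cc5ccc(OC)c(OC)c5)nnc4s3)c2c1`, gives 11.6% in this assay; its number lies within the scatter of both compound 1 and compound 3, so no order among the three can be read from these values. The difference between the core of compound 2 and the core of compound 1 is not broken down here.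

Compound 4, `COc1ccc(Cc2nnc3sc(Cc4c[nH]c5ccccc45)nn23)cc1OC`, has not yet been measured. It differs from compound 2 by hydrogen in place of methoxy on an aromatic carbon, and the place of the change is described in the same words as for the pair of compound 1 and compound 3, so this is the same change, occurring twice among the compounds shown. Because the measured step of a number 2.1 percentage points higher from compound 1 to compound 3 (within the scatter) stayed within the scatter, compound 4 is expected to show a step of similar size, a number 2.4 percentage points higher from compound 2 to compound 4 (within the scatter), in this assay. Resting on that single precedent, compound 4 is estimated to give 14% in this assay, with a plausible range from 6% to 22%.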

Compound 4, a percentage reported as inhibition, in the whole organism at one dose (the size of the read-out at that dose, not a potency): 26.8%
Compound 4: middle estimate off by 12.8 percentage points, on the low side; the whole stated range lies below it.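

In this assay, hydrogen in place of methoxy on an aromatic carbon of the six-membered aromatic ring gives a step that stands clear of the scatter on the core of compound 2: a number 15.2 percentage points higher from compound 2 to compound 4 (beyond the scatter). Set beside the earlier step on the core of compound 1, a number 2.1 percentage points higher from compound 1 to compound 3 (within the scatter), this larger step does not separate the two cores: the same change on two cores in this assay, a number 2.1 percentage points higher (within the scatter) from compound 1 to compound 3 and a number 15.2 percentage points higher (beyond the scatter) from compound 2 to compound 4, 13.1 percentage points apart, within the scatter of two such steps. The pairs therefore show that this change can be followed by a clear rise on one core, but they do not show that the size of the step depends on the core, nor that a step of one fixed size carries from one core to the other, and two pairs are too few to settle either point.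

The compounds shown leave open what other groups at this same place would do, such as a fluorine atom, a hydroxyl or an amine, since only methoxy and hydrogen appear there. They also leave open how far any of these steps would hold at another dose or another time, since every number here comes from a single dose and a single stated time.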